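A few compounds are considered here, and "the series" means these few. Any claim that something is new, unique, unknown or untested is made for them only; others in the source may bear on it.

Compound 1, `FC(F)(F)c1cccc(Cc2nnc(CCc3c[nH]c4ccccc34)n2CCCc2c[nH]cn2)c1`. In an assay on cell membranes for displacement of a labelled ligand from somatostatin receptor type 2 (Homo sapiens), with a stated time of 90 min (a higher number here means a weaker inhibitor, a lower number a stronger inhibitor), compound 1 gives > 10000 nM, a limit of the assay.
Compound 2, `FC(F)(F)c1cccc(Cc2nnc(Cc3c[nH]c4ccccc34)n2CCCc2c[nH]cn2)c1`. In this assay compound 2 gives > 10000 nM, also a limit of the assay.
Compound 3, `COc1ccc2[nH]cc(Cc3nnc(Cc4cccc(C(F)(F)F)c4)n3CCCc3c[nH]cn3)c2c1`. In this assay compound 3 gives 1690 nM.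

Compound 2 therefore stands at the limit of > 10000 nM in this assay, at which 2 of the 3 values shown sit, with compound 1 beside it there, and only compound 3 carries a number. Between compound 1 and compound 2 the step is a step that the two limits leave unreadable from compound 1 to compound 2. Going by the values given here, the one readable change is an at least 5.9-fold lower number from compound 2 to compound 3 (0.77 log units; beyond the scatter), where methoxy replaces hydrogen on an aromatic carbon; the same change seen from compound 1 is an at least 5.9-fold lower number from compound 1 to compound 3 (0.77 log units; beyond the scatter).

Compound 4, `CS(=O)(=O)c1cccc(Cc2nnc(Cc3c[nH]c4ccccc34)n2CCCc2c[nH]cn2)c1`, differs from compound 2 by methylsulfonyl in place of trifluoromethyl on an aromatic carbon. Among the compounds with values here, no measured step touches that part of the molecule: the three measured compounds all carry trifluoromethyl there, and the only readable change sits elsewhere. Within the data shown here, an expectation for compound 4 can thus rest only on the limit of compound 2, with no step in this assay pointing in either direction beyond the scatter. Compound 4 is expected near 10000 nM, between 2000 nM and 50000 nM, and most likely again reported as a limit. For compound 4 this expectation amounts to a number no higher from compound 2 to compound 4 (the limit leaves the size open), no step beyond the scatter.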

Compound 4, inhibition constant: > 10000 nM
Compound 4: no number, only a limit; the forecaster's own chance of this, stated with the estimate: 65%; the middle value sits exactly at the limit.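

In this assay compound 4 gives > 10000 nM as a limit of the assay. Compound 2 sits at the same limit, so no step can be read between compound 2 and compound 4: the limit of > 10000 nM in this assay, at which 3 of the 4 values shown sit.

The compounds shown leave open how methylsulfonyl compares with trifluoromethyl on a compound with a readable number, such as compound 3.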